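This account rests on a few compounds, and the source may have more. Where it says the series, first, only, none or still open, it means among the compounds named here.

Within the data shown here, compound 2 `COc1cccc(-c2nc(Cc3c[nH]c4ccccc34)no2)c1` supplies the only number in an ADME assay on cells (Splenocyte, Mus musculus, strain BALB/c) for cytotoxicity, read by CCK-8 assay, with a stated time of 48 h; on this read-out higher numbers stand for lower toxicity in this test and lower numbers for higher toxicity in this test: here compound 2 gives 18400 nM. Compound 1 `COc1cc(-c2nc(Cc3c[nH]c4ccccc34)no2)cc(OC)c1OC` reports a limit in this assay, compound 1 giving > 50000 nM. Compound 3 `COc1cc(OC)cc(-c2nc(Cc3c[nH]c4ccccc34)no2)c1` awaits measurement in this assay. It differs from compound 2 by methoxy in place of hydrogen on an aromatic carbon. Among the measured compounds shown here, no step between measured compounds is available for this change, so its size is an expectation only. The expected step is a 1.6-fold higher number from compound 2 to compound 3 (0.21 log units; within the scatter), pointing toward lower toxicity in this assay. For compound 3 the estimate is 30000 nM, with a range from 12000 nM to 75000 nM.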

Compound 3, half-maximal cytotoxic concentration: > 50000 nM
Compound 3 gave a limit, no number (the forecaster's own chance of this, stated with the estimate: 30%); middle value at least 1.6-fold (0.22 log units) away from the limit.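

In this assay, among these compounds, methoxy in place of hydrogen, meta to a large group and meta to a methoxy group, gives the first readable step: an at least 2.7-fold higher number from compound 2 to compound 3 (0.43 log units; beyond the scatter). As far as these compounds go, the change therefore moves the read-out toward lower toxicity, and the true size of the step remains open. The step between compound 1 and compound 3 cannot be read, so any effect of the further methoxy of compound 1 stays hidden: the limit of > 50000 nM in this assay, at which 2 of the 3 values shown sit.

From the compounds shown here alone, how an amine, a hydroxyl or a carboxylic acid at this position would compare remains open.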